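Ortho substituent exchange on the anilino ring of compound 2

The compounds below may be only part of what the source reports. "The series", "measured", "known", "first", "only" and "open" are said of these compounds alone.

Compound 1, `C#CCSc1nc(Nc2ccc(Cl)cc2)c(C#N)c(-c2ccccc2)n1`, was tested in a functional assay on MCF7 cells (Homo sapiens) for inhibition, read by MTT assay, with a stated time of 72 h (on this read-out higher numbers stand for weaker inhibition and lower numbers for stronger inhibition), and gives > 128000 nM, which is a limit of the assay rather than a number. Compound 2, `N#Cc1c(Nc2ccccc2Cl)nc(SCc2cn(Cc3ccccc3Cl)nn2)nc1-c1ccccc1`, gives in this assay 1950 nM. Compound 3, `COc1ccccc1Nc1nc(SCc2cn(Cc3ccccc3Cl)nn2)nc(-c2ccccc2)c1C#N`, gives in this assay 6170 nM.

Among the two numbers shown, compound 2 holds the lowest, and the step of a 3.2-fold higher number from compound 2 to compound 3 (0.50 log units; beyond the scatter) sets compound 3 apart from it. The unmeasured compound 4, `Cc1ccccc1Nc1nc(SCc2cn(Cc3ccccc3Cl)nn2)nc(-c2ccccc2)c1C#N`, differs from compound 2 by methyl in place of chloro on an aromatic carbon. For the measured compounds named here, the only measured step that bears on this place is the one from compound 2 to compound 3, where methoxy took the place of chloro on the same aromatic carbon and the number rose modestly. The change to methyl is a smaller alteration at the same position, and no further comparison is available, so a step within or just beyond the scatter is expected, if anything toward a higher number. Compound 4 is therefore estimated at 2700 nM, with a range from 1000 nM to 7500 nM, which corresponds to an expected step of a 1.4-fold higher number from compound 2 to compound 4 (0.14 log units; within the scatter).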

Compound 4, half-maximal inhibitory concentration: 7950 nM
Compound 4: the middle estimate sits 2.9-fold (0.47 log units) below what was measured, and the stated range ends below it.
By their numbers in this assay, from the lowest: compound 2; then compounds 3 and 4 (each within the scatter of the next). At a limit, above all of these: compound 1.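

In this assay, exchanging chloro for methyl gives a 4.1-fold higher number from compound 2 to compound 4 (0.61 log units; beyond the scatter), so a second group now joins methoxy in moving the number beyond the scatter at this place. The two replacements are not separated from each other, with a 1.3-fold higher number from compound 3 to compound 4 (0.11 log units; within the scatter), which leaves compound 2, with its 2-chlorophenyl group, holding the lowest number of the three compounds that differ only here. Nothing in the data at hand accounts for why chloro stands apart from methyl and methoxy.

As far as these compounds go, whether a fluoro, a bromo or a trifluoromethyl group would keep the number of compound 2 or join the other two remains open. So does the outcome with a plain phenyl ring carrying no group at this place, which would show what chloro itself contributes to the number.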